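Methyl for Chloro on the Aryl Ring of Compound 1

The source may report more compounds than this note shows. Statements on the series, on what has been measured and on what is new or still open speak of the compounds shown alone.

Compound 1 `O=C1CSC(c2ccc(Cl)cc2)N1CCN1CCCCC1`: 90% in an ADME assay on Vero cells (Chlorocebus sabaeus) for cytotoxicity, read by neutral red uptake, tested at 12.3 ug/mL; a higher number here means a weaker effect of the compound at the concentration tested, a lower number a stronger effect
Compound 2 `COc1ccccc1C1SCC(=O)N1CCN1CCCCC1`: 100%
Compound 3 `O=C1CSC(c2cccc(O)c2)N1CCN1CCCCC1`: 100%

The three numbers lie within the usual scatter of one another, so compound 1 is not separated from compound 2 or from compound 3 on this read-out. Compound 4 `Cc1ccc(C2SCC(=O)N2CCN2CCCCC2)cc1` is the next step from compound 1: methyl in place of chloro on an aromatic carbon. Among the compounds with values here, the one measured step that bears on it swaps the group on the same aromatic ring, a number 10 percentage points higher from compound 1 to compound 3 (within the scatter), and stays within the scatter. On that basis the step to compound 4 is expected to be a number 5 percentage points higher from compound 1 to compound 4 (within the scatter), with no movement beyond the scatter. Compound 4 is therefore estimated at 95%, in a range from 80% to 100%.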

Compound 4, a percentage reported as activity, at one concentration (the size of the read-out at that concentration, not a potency): 100%
Compound 4: middle estimate off by 5 percentage points, on the low side, and the stated range covers the measured number.
By their numbers in this assay, from the lowest: compounds 1, 2, 3 and 4 (each within the scatter of the next).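

In this assay the change from 4-chlorophenyl to 4-methylphenyl gives a number 10 percentage points higher from compound 1 to compound 4 (within the scatter) as the first step shown at this aromatic carbon itself, so swapping chloro for methyl here does not separate the two compounds. The methyl compound also sits with the hydroxy compound, with no change at the digits printed from compound 3 to compound 4 (within the scatter) on this read-out. No evidence at hand bears on these readings.

The compounds shown leave open whether an amine or a carboxylic acid on this aromatic carbon would move the number beyond the scatter.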